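The compounds below may be only part of what the source reports. "The series", "measured", "known", "first", "only" and "open" are said of these compounds alone.

Measured so far:
compound 1 `O=C(Nc1cccc(-n2cc(-c3ccncc3)c(-c3cc(O)cc(Cl)c3)n2)c1)Nc1ccc(Cl)c(C(F)(F)F)c1` – -84%
compound 2 `COc1cc(Cl)cc(-c2nn(-c3cccc(NC(=O)Nc4ccc(Cl)c(C(F)(F)F)c4)c3)cc2-c2ccncc2)c1` – -100%

Going by the values given here, in a functional assay on U-251 cells (Homo sapiens) for inhibition, read by sulforhodamine B assay, with a stated time of 48 h, tested at 100 uM (a higher number here means a weaker effect of the compound at the concentration tested, a lower number a stronger effect), compound 2 holds the lowest of the two numbers; its nearest neighbour is compound 1, and the only measured step, a number 16 percentage points lower from compound 1 to compound 2 (beyond the scatter), concerns the oxygen on the aromatic ring and nothing else. Compound 3 `COc1cc(Cl)cc(-c2nn(-c3cccc(NC(=O)c4cccc(C(F)(F)F)c4)c3)cc2-c2ccncc2)c1` differs from compound 2 by 3-(trifluoromethyl)phenyl in place of (4-chloro-3-(trifluoromethyl)phenyl)amino on a carbonyl carbon. Among the compounds with values here, no measured step touches the carbonyl side, so nothing bears on this change. Without a comparable step, a moderate weakening is expected as a guess, with wide bounds: the expected step is a number 25 percentage points higher from compound 2 to compound 3 (beyond the scatter). For compound 3 the estimate is -75%, between -100% and -30%.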

Compound 3, a percentage reported as activity, at one concentration (the size of the read-out at that concentration, not a potency): 41%
Compound 3: the middle estimate sits 116 percentage points below what was measured; measured number above the stated range.
By their numbers in this assay, from the lowest: compound 2; then compound 1; then compound 3.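

Replacing (4-chloro-3-(trifluoromethyl)phenyl)amino with 3-(trifluoromethyl)phenyl on the carbonyl carbon gives, in this assay, a number 141 percentage points higher from compound 2 to compound 3 (beyond the scatter), so the carbonyl side matters far more here than the oxygen substituent. The read-out also changes sign: compound 2 gives -100% and compound 3 gives 41%. No measurement explains this loss of effect. The change removes the amino nitrogen and the chlorine together, and their contributions remain unseparated. A 4-chloro-3-(trifluoromethyl)phenyl directly on the carbonyl carbon, or a methylene in place of the amino nitrogen, would address this.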